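Trading a bromopropyl ether for an acetate on a brominated diaryl ether

The source may hold more compounds than are shown below. What is called first, only, known or untested is meant among the compounds shown, and "the series" means these compounds.

The measured compounds so far:
compound 1 `OCCOc1c(Br)cc(Br)cc1Oc1ccc(Br)cc1Br`, which in a functional assay on HL-60 cells (Homo sapiens) for cytotoxicity, read by MTT assay, with a stated time of 24 h (a lower number here means a stronger inhibitor, a higher number a weaker inhibitor), gives 28.2 ug/mL
compound 2 `BrCCCOc1c(Br)cc(Br)cc1Oc1ccc(Br)cc1Br`, which in this assay gives 29.9 ug/mL

Compound 2 carries the higher of the two numbers, but its separation from compound 1 is tiny: the step of a 1.1-fold higher number from compound 1 to compound 2 (0.03 log units; within the scatter) lies within the scatter, so the two compounds cannot be told apart on these data.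

Compound 3 `CC(=O)Oc1c(Br)cc(Br)cc1Oc1ccc(Br)cc1Br` shares the same brominated diaryl ether core and differs from compound 2 only at the oxygen on the aromatic ring: acetyl in place of 3-bromopropyl on an oxygen on an aromatic ring

Going by the values given here, the one measured step, from compound 1 to compound 2, also altered the group on that oxygen, swapping a hydroxy for a bromomethyl at the chain end, and it moved the number only by a 1.1-fold higher number from compound 1 to compound 2 (0.03 log units; within the scatter). That step bears on the present one, though less directly, since compound 3 removes the chain and puts an acetyl there instead. With no step beyond the scatter in hand, the expectation for compound 3 in this assay is a change of about a 1.0-fold lower number from compound 2 to compound 3 (0.01 log units; within the scatter), that is, none beyond the scatter. Compound 3 is therefore estimated at 29 ug/mL, within a range of 14 ug/mL to 60 ug/mL.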

Compound 3, half-maximal inhibitory concentration: 29.9 ug/mL
Estimate against measurement, compound 3: 1.0-fold (0.01 log units) below; measured number inside the range.
By their numbers in this assay, from the lowest: compounds 1, 2 and 3 (each within the scatter of the next).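

In this assay, acetyl in place of 3-bromopropyl on the oxygen on the aromatic ring gives (no change at the digits printed from compound 2 to compound 3 (within the scatter)), and acetyl in place of 2-hydroxyethyl at the same oxygen gives (a 1.1-fold higher number from compound 1 to compound 3 (0.03 log units; within the scatter)). The earlier step altered only the end of a chain, whereas this change replaces the whole chain with a group that loses the bromine and brings a double bond outside aromatic rings and a hydrogen-bond acceptor, yet compound 1, compound 2 and compound 3 still cannot be told apart in this assay. No supporting data bear on why these three groups read alike.

Going by these compounds, all three compounds carry a group on this oxygen, so it remains open whether a free hydroxy, a chain ending in an amine, a carboxylic acid or a much longer chain would also read the same. The agreement so far covers only 3-bromopropyl, 2-hydroxyethyl and acetyl on the shared core, and these compounds say nothing about how much the bromines on that core contribute.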